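Replacing 4-methoxyphenyl with 2-chlorophenyl: a small expected step

The source may hold more compounds than are shown below. What is called first, only, known or untested is meant among the compounds shown, and "the series" means these compounds.

Measured so far in a functional assay on MCF7 cells (Homo sapiens) for cytotoxicity, read by MTT assay, with a stated time of 24 h; on this read-out higher numbers stand for weaker inhibition and lower numbers for stronger inhibition
Compound 1 `CCNc1cc(-c2ccc(NC(=O)Nc3ccc(OC)cc3)cc2C)ccn1` gives 9950 nM
Compound 2 `CCNc1cc(-c2ccc(NC(=O)Nc3ccc(C)cc3)cc2C(F)(F)F)ccn1` gives 9470 nM
Compound 3 `CCNc1cc(-c2ccc(NC(=O)Nc3ccc(OC)cc3)cc2C(F)(F)F)ccn1` gives 5740 nM

Compound 3 lies within the usual scatter of both compound 1 and compound 2, so these three cannot be ranked. Compound 4 `CCNc1cc(-c2ccc(NC(=O)Nc3ccccc3Cl)cc2C(F)(F)F)ccn1` has 2-chlorophenyl in place of 4-methoxyphenyl on an amide-type nitrogen. Two measured steps offer some guidance. Trifluoromethyl in place of methyl gave a small change (a 1.7-fold lower number from compound 1 to compound 3 (0.24 log units; within the scatter)). Methoxy in place of methyl, on the ring that is now replaced, also gave a small change (a 1.6-fold lower number from compound 2 to compound 3 (0.22 log units; within the scatter)). For the measured compounds named here, no chlorine-bearing compound has been measured, so this guidance is limited. In this assay no step beyond the scatter is expected, and the estimated change is small (a 1.2-fold higher number from compound 3 to compound 4 (0.09 log units; within the scatter)). For compound 4 the expected value is 7000 nM (estimated range 3000 nM to 16000 nM).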

Compound 4, half-maximal inhibitory concentration: 3680 nM
For compound 4 the middle estimate is 1.9-fold (0.28 log units) above the measured one; the measured number falls inside the stated range.
By their numbers in this assay, from the lowest: compounds 4, 3, 2 and 1 (each within the scatter of the next, the first and the last beyond it).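

In this assay, for the compounds shown here, the place on the amide-type nitrogen tolerates a chlorine-bearing ring: 2-chlorophenyl in place of 4-methoxyphenyl gives a step within the scatter (a 1.6-fold lower number from compound 3 to compound 4 (0.19 log units; within the scatter)). 2-Chlorophenyl in place of 4-methylphenyl gives the first step at this place to pass the scatter, though only a modest one (a 2.6-fold lower number from compound 2 to compound 4 (0.41 log units; beyond the scatter)). No measurement here accounts for either step. Still open, as far as these compounds go, is how an amine or a carboxylic acid in place of the chlorine would read out, and whether 3-chlorophenyl or 4-chlorophenyl would match 2-chlorophenyl.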